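Aryl amide series: methyl-to-chloro step on compound 3

The compounds below may be only part of what the source reports. "The series", "measured", "known", "first", "only" and "open" are said of these compounds alone.

Compound 3 `COc1ccc2occ(C(=O)Nc3ccc(C)cc3)c(=O)c2c1` gives the highest number of the three in an assay on cells for inhibition of Amine oxidase [flavin-containing] B (Homo sapiens), read by fluorescence and Amplex Red, using microsomes, with a stated time of 15 min (a higher number here means a weaker inhibitor, a lower number a stronger inhibitor), at 211 nM. Compound 1 `COc1ccc2occ(C(=O)Nc3ccccc3)c(=O)c2c1` gives 41.8 nM and compound 2 `COc1ccc2occ(C(=O)Nc3cccc(Cl)c3)c(=O)c2c1` gives 3.94 nM. The measured steps are a 5.0-fold higher number from compound 1 to compound 3 (0.70 log units; beyond the scatter) and a 54-fold higher number from compound 2 to compound 3 (1.73 log units; beyond the scatter). Compound 4 `COc1ccc2occ(C(=O)Nc3ccc(Cl)cc3)c(=O)c2c1` differs from compound 3 by chloro in place of methyl on an aromatic carbon. Among the measured compounds shown here, two measured steps bear on this: a 5.0-fold higher number from compound 1 to compound 3 (0.70 log units; beyond the scatter), which the new step undoes, and an 11-fold lower number from compound 1 to compound 2 (1.03 log units; beyond the scatter), although the structures show the chloro of compound 2 on a different ring carbon than in compound 4. Both point the same way, so a large drop in this assay is expected, a 14-fold lower number from compound 3 to compound 4 (1.15 log units; beyond the scatter). Compound 4 is therefore estimated at 15 nM, within 4 nM to 60 nM.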

Compound 4, half-maximal inhibitory concentration: 10.3 nM
The estimate for compound 4 lay 1.5-fold (0.16 log units) above the measured number; the measured number falls inside the stated range.
By their numbers in this assay, from the lowest: compound 2; then compound 4; then compound 1; then compound 3.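

Working in this assay, the aromatic carbon para to a large group separates chloro from methyl sharply (a 20-fold lower number from compound 3 to compound 4 (1.31 log units; beyond the scatter)), and chloro in place of hydrogen there lowers the number (a 4.1-fold lower number from compound 1 to compound 4 (0.61 log units; beyond the scatter)), whereas methyl raised it. Chloro therefore lowers the number in both compound 2 and compound 4, though 4-chlorophenyl in place of 3-chlorophenyl still gives a modest rise (a 2.6-fold higher number from compound 2 to compound 4 (0.42 log units; beyond the scatter)). No measurement at hand accounts for these steps.

Still open, going by these compounds, is how other groups on this carbon, such as fluoro, methoxy or an amine, compare with chloro. Also open, on these data alone, is what two chloro groups on the same ring would give.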